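The compounds below may be only part of what the source reports. "The series", "measured", "known", "first", "only" and "open" are said of these compounds alone.

Measured compounds:
Compound 1, `N#C[C@@]1(NC(=O)[C@@H](CC(=O)N2CCOCC2)CC2CCCCC2)CCN(C2CCCCCC2)C1`, gives 23 nM.
Compound 2, `N#C[C@@]1(NC(=O)[C@@H](CC(=O)N2CCOCC2)CC2CCc3ccccc3C2)CCN(C2CCCCC2)C1`, gives 1.9 nM.

Both numbers come from an assay on isolated protein for inhibition of cathepsin S (Homo sapiens); on this read-out higher numbers stand for weaker inhibition and lower numbers for stronger inhibition. For the measured compounds named here, on these two numbers compound 2 stands lowest; its only neighbour is compound 1, whose number is higher by a margin beyond the usual scatter. Compound 3, `N#C[C@@]1(NC(=O)[C@@H](CC(=O)N2CCOCC2)CC2CCCCC2)CCN(C2CCCCC2)C1`, has not yet been measured. It differs from compound 2 in one place: cyclohexyl in place of 1,2,3,4-tetrahydronaphthalen-2-yl on a saturated chain carbon, two bonds along the chain from a carbonyl carbon. Going by the values given here, no step between measured compounds isolates this change, so its size cannot be read directly from the data. Compound 1 carries cyclohexyl on the same saturated chain carbon and gives 23 nM, a higher number than compound 2 shows. The step from compound 2 to compound 3 is therefore expected to run upward, towards weaker inhibition, by roughly a 6.3-fold higher number from compound 2 to compound 3 (0.80 log units; beyond the scatter). Compound 3 is expected to give about 12 nM in this assay, with a likely range from 4 nM to 40 nM.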

Compound 3, half-maximal inhibitory concentration: 23 nM
Beside the measured number, compound 3's estimate is 1.9-fold (0.28 log units) below it; the range from low to high includes it.
By their numbers in this assay, from the lowest: compound 2; then compounds 1 and 3 (each within the scatter of the next).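

In this assay, the change from 1,2,3,4-tetrahydronaphthalen-2-yl to cyclohexyl on a saturated chain carbon, two bonds along the chain from a carbonyl carbon, can now be read alone, and it gives a 12-fold higher number from compound 2 to compound 3 (1.08 log units; beyond the scatter), a large step. The earlier pair differed in two places and could not isolate it. The change of cycloheptyl to cyclohexyl on an amine nitrogen in a ring can also now be read alone, and it gives no change at the digits printed from compound 1 to compound 3 (within the scatter), so among these compounds only the change on the chain carbon moves the number beyond the scatter.

Still open, from the compounds shown here alone, is how phenyl or a pyridine ring on that chain carbon would read, and whether cycloheptyl and cyclohexyl also match when 1,2,3,4-tetrahydronaphthalen-2-yl is present. Nothing available accounts for the size of the step on the chain carbon.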